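A few compounds are considered here, and "the series" means these few. Any claim that something is new, unique, unknown or untested is made for them only; others in the source may bear on it.

Measured in an ADME assay for metabolic stability, at pH 3.0; a lower number here means that the compound disappears faster, a higher number that the compound lasts longer:
- compound 1 `COc1ccc2c(c1)COP(=O)(OCC1CCC(n3cnc4c(N)ncnc43)O1)O2`: 12.2 h
- compound 2 `Cc1cc(C)c2c(c1)COP(=O)(OCC1CCC(n3cnc4c(N)ncnc43)O1)O2`: 10.3 h

These are the only two half-lives available at this point. In this assay, compound 1 gives 12.2 h and compound 2 gives 10.3 h. The two numbers lie within the usual scatter of each other, so compound 1 does not stand apart from compound 2.

The next compound to be tested is compound 3 `Nc1ncnc2c1ncn2C1CCC(COP2(=O)OCc3ccccc3O2)O1`. Compared with compound 1, it carries hydrogen in place of methoxy on an aromatic carbon. The rest of the structure is unchanged.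

For the measured compounds named here, no measured pair of compounds differing in one place shows what such a change does, so the data offer no direct guide to its size or direction. Going by the values given here, the only anchor is that compound 1 at 12.2 h and compound 2 at 10.3 h fall within the scatter of each other. On that basis, no step beyond the scatter is expected in this assay, in either direction.

The expected change is a 1.1-fold lower number from compound 1 to compound 3 (0.04 log units; within the scatter).

Compound 3 is estimated at 11 h, with an expected range of 6 h to 20 h.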

Compound 3, half-life: 12.9 h
Compound 3: the middle estimate sits 1.2-fold (0.07 log units) below what was measured, within the range that was stated.
By their numbers in this assay, from the lowest: compounds 2, 1 and 3 (each within the scatter of the next).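

In this assay, for the compounds shown here, hydrogen in place of methoxy on an aromatic carbon gives a 1.1-fold higher number from compound 1 to compound 3 (0.02 log units; within the scatter), the only step so far that can be read at a single place. It shows that at this position, on the six-membered aromatic ring of carbon only, the half-life of compound 3 stays within the scatter of that of compound 1 without the methoxy group, something the earlier pair of compound 1 and compound 2, which differ in more than one place, could not show. Nothing available explains this result, and no measurement bears on what lies behind it.

As far as these compounds go, this single step compares only methoxy and hydrogen at this aromatic carbon, so it remains open whether an amine, a carboxylic acid, a chlorine atom or a longer chain such as butoxy would also leave the half-life within the scatter. It also leaves open whether the same change at another aromatic carbon of the shared core, or on a core carrying the methyl groups of compound 2, would give a similarly small step.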